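Replacing a Cyclobutylsulfanyl Group with an Ethylpyrimidinyl Ring

The source may report more compounds than this note shows. Statements on the series, on what has been measured and on what is new or still open speak of the compounds shown alone.

Within the data shown here, compound 1 `Cc1nc(S(C)(=O)=O)ccc1Oc1ncnc(OC2CCN(C(=O)SC(C)(C)C)CC2)c1F` gives 30.7 nM in a functional assay on isolated protein for inhibition of Glucose-dependent insulinotropic receptor (Rattus norvegicus), read by HTRF and cAMP accumulation (a lower number here means that less compound is needed, a higher number that more compound is needed for the effect), and compound 2 `Cc1nc(S(C)(=O)=O)ccc1Oc1ncnc(OC2CCN(C(=O)SC3CCC3)CC2)c1F` gives 77.4 nM, the higher of the two numbers; the only measured step, a 2.5-fold higher number from compound 1 to compound 2 (0.40 log units; beyond the scatter), is the swap of one group on the sulfur. Compound 3 `CCc1cnc(C(=O)N2CCC(Oc3ncnc(Oc4ccc(S(C)(=O)=O)nc4C)c3F)CC2)nc1` differs from compound 2 by 5-ethylpyrimidin-2-yl in place of cyclobutylsulfanyl on a carbonyl carbon. Among the measured compounds shown here, no measured step changes the carbonyl substituent itself, so the prior step gives only a sense of scale, not direction. Compound 3 is therefore expected to show a 1.3-fold lower number from compound 2 to compound 3 (0.11 log units; within the scatter), and its estimated value in this assay is 60 nM, within a range from 20 nM to 200 nM.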

Compound 3, half-maximal effective concentration: 40.8 nM
The estimate for compound 3 lay 1.5-fold (0.17 log units) above the measured number; low and high end bracket the measured number.
By their numbers in this assay, from the lowest: compounds 1, 3 and 2 (each within the scatter of the next, the first and the last beyond it).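

The measured step shows that the carbonyl carbon on the ring nitrogen need not carry a sulfur-linked group: 5-ethylpyrimidin-2-yl, a six-membered aromatic ring, gives a 1.9-fold lower number from compound 2 to compound 3 (0.28 log units; within the scatter) and also a 1.3-fold higher number from compound 1 to compound 3 (0.12 log units; within the scatter) in this assay. Both steps lie within the scatter, so this swap separates compound 3 from neither sulfur-linked compound. Nothing available explains this result.

The compounds shown leave open what the ethyl group contributes. They also do not show whether an unsubstituted pyrimidin-2-yl, a phenyl or a pyridine ring on the same carbonyl carbon would give a similar number.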